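Swapping Bromo for Chloro on an Aromatic Carbon

The source may hold more compounds than are shown below. What is called first, only, known or untested is meant among the compounds shown, and "the series" means these compounds.

Of the compounds shown here, three have so far been measured in a functional assay on P388 cells (Mus musculus) for inhibition; a lower number here means a stronger inhibitor, a higher number a weaker inhibitor. Compound 1 `O=C(/C=C/c1cccc([N+](=O)[O-])c1)c1ccccc1` gives 15300 nM, compound 2 `O=C1/C(=C/c2ccc(Cl)cc2Cl)CCCc2ccccc21` gives 14000 nM, and compound 3 `O=C1/C(=C/c2ccccc2Br)CCCc2ccccc21` gives 19800 nM. Compound 3 therefore stands within the scatter of both other compounds, and these numbers do not separate the three. Among the compounds with values here, no two of them differ in one place alone, so no measured step is available as a guide.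

The next compound is compound 4 `O=C1/C(=C/c2ccccc2Cl)CCCc2ccccc21`, which has chloro in place of bromo on an aromatic carbon, ortho to a large group, and otherwise matches compound 3. The change is chloro in place of bromo on an aromatic carbon. Within the data shown here, the only other measured compound carrying chloro is compound 2, at 14000 nM, and that value lies within the scatter of the one for compound 3. This offers no reason to expect a large move in this assay, though compound 2 also differs elsewhere and is only a loose guide. The estimated 1.2-fold lower number from compound 3 to compound 4 (0.07 log units; within the scatter) is expected to stay within the scatter, with no firm direction. For compound 4 the estimated value is 17000 nM, with an expected range from 9000 nM to 32000 nM.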

Compound 4, half-maximal inhibitory concentration: 12700 nM
Compound 4: middle estimate off by 1.3-fold (0.13 log units), on the high side; the measured number falls inside the stated range.
By their numbers in this assay, from the lowest: compounds 4, 2, 1 and 3 (each within the scatter of the next).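

Within the data shown here, the first steps between compounds that differ in one place now stand in this assay, and the step of a 1.6-fold lower number from compound 3 to compound 4 (0.19 log units; within the scatter) comes with chloro in place of bromo on an aromatic carbon, ortho to a large group. That step stays within the scatter, so at this position the assay does not tell these two halogens apart. The step of a 1.1-fold lower number from compound 2 to compound 4 (0.04 log units; within the scatter) comes with hydrogen in place of chloro on an aromatic carbon and is also within the scatter, so this second chloro has no measurable bearing on the number here, and nothing available speaks to how either change acts in these cells.

What the compounds shown leave open is whether anything at this position can move the number beyond the scatter, since only bromo and chloro have been seen there, and a methoxy group, an amine or a carboxylic acid on the same aromatic carbon would test that more sharply. They also leave open whether hydrogen at this position would give a number any different from those of compound 3 and compound 4.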